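Pyridin-3-ylmethyl in Place of a Halogenated Benzyl Group

The source may report more compounds than this note shows. Statements on the series, on what has been measured and on what is new or still open speak of the compounds shown alone.

Compound 1, `COc1ccc2[nH]c3c(c2c1)CCNC31CCN(Cc2ccc(Cl)cc2Cl)CC1`, gives 1800 nM in an assay on FRT cells for positive allosteric modulation of Cystic fibrosis transmembrane conductance regulator variant N1303K (Homo sapiens), in the presence of a further agent that is not named here; on this read-out lower numbers stand for an effect already at smaller amounts and higher numbers for an effect only at larger amounts of compound.
Compound 2, `COc1ccc2[nH]c3c(c2c1)CCNC31CCN(Cc2ccc(Br)cc2F)CC1`, gives 1600 nM.
Compound 3, `COc1ccc2[nH]c3c(c2c1)CCNC31CCN(C(C)c2ccccc2)CC1`, gives 20000 nM.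

Compound 2 shows the lowest number of the three, yet the step of a 1.1-fold lower number from compound 1 to compound 2 (0.05 log units; within the scatter) is within the scatter, so compounds 1 and 2 cannot be set apart; only compound 3 stands clearly away from both, as the steps of an 11-fold higher number from compound 1 to compound 3 (1.05 log units; beyond the scatter) and a 13-fold higher number from compound 2 to compound 3 (1.10 log units; beyond the scatter) show.

Compound 4, `COc1ccc2[nH]c3c(c2c1)CCNC31CCN(Cc2cccnc2)CC1`, has not yet been measured. It differs from compound 2 in one place: pyridin-3-yl in place of 4-bromo-2-fluorophenyl on a saturated chain carbon bound to an amine nitrogen in a ring. Among the measured compounds shown here, two measured steps bear on this. The step of a 1.1-fold lower number from compound 1 to compound 2 (0.05 log units; within the scatter) tells that exchanging one halogenated ring for another leaves the number unchanged, and the step of a 13-fold higher number from compound 2 to compound 3 (1.10 log units; beyond the scatter) tells that losing both halogens costs a great deal, although compound 3 also changes the chain carbon next to the ring, so that step does not isolate the aryl change. For the measured compounds named here, no measured compound carries a ring with a nitrogen in this position, so the effect of the entering acceptor is unknown. On balance a rise of moderate size is expected, a 3.1-fold higher number from compound 2 to compound 4 (0.49 log units; beyond the scatter). Compound 4 is therefore estimated at 5000 nM, with a range from 1600 nM to 16000 nM.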

Compound 4, half-maximal effective concentration: 17000 nM
Compound 4: middle estimate off by 3.4-fold (0.53 log units), on the low side; the whole stated range lies below it.
By their numbers in this assay, from the lowest: compounds 2 and 1 (each within the scatter of the next); then compounds 4 and 3 (each within the scatter of the next).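

The change from 4-bromo-2-fluorophenyl to pyridin-3-yl on a saturated chain carbon bound to an amine nitrogen in a ring gives an 11-fold higher number from compound 2 to compound 4 (1.03 log units; beyond the scatter), and the change from 2,4-dichlorophenyl gives a 9.4-fold higher number from compound 1 to compound 4 (0.98 log units; beyond the scatter). This shows that replacing the aryl ring alone, with the chain carbon left unchanged, is enough to produce a clear rise in this assay, whereas the only earlier rise of this kind, in compound 3, came with a change at the chain carbon as well. The step of a 1.2-fold lower number from compound 3 to compound 4 (0.07 log units; within the scatter) lies within the scatter, so these two different replacements of the halogenated benzyl groups cannot be set apart, and no measurement shown here explains the rise.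

The compounds shown leave open whether the rise follows the entry of the ring nitrogen or the departure of the halogens, as both change together in this step. A plain benzyl group on the amine nitrogen in a ring, or a pyridin-3-ylmethyl group carrying a bromine, would separate these two changes.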